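A few compounds are considered here, and "the series" means these few. Any claim that something is new, unique, unknown or untested is made for them only; others in the source may bear on it.

Working notes on the series. In a functional assay on SW480 cells (Homo sapiens) for antiproliferative activity, read by MTT assay, with a stated time of 48 h (a higher number here means a weaker inhibitor, a lower number a stronger inhibitor), compound 1 (`CCCCCCC(CCO)n1cnc2c(N(C)C)ncnc21`) gives > 50000 nM, which is a limit. Compound 2 (`CCCCCCC(CCO)n1cnc2c(N)ncnc21`) gives > 50000 nM, also a limit. Compound 3 (`CCCCCCC(CCO)n1cnc2cncnc21`) gives > 50000 nM, again a limit. All three therefore sit at the limit of > 50000 nM in this assay, at which 3 of the 3 values shown sit.

Compound 4 (`CCCCCCCCCCC(CCO)n1cnc2c(N(C)C)ncnc21`) differs from compound 1 by butyl in place of hydrogen on a saturated chain carbon, seven bonds along the chain from an aromatic nitrogen. Three measured steps exist: a step that the two limits leave unreadable from compound 1 to compound 2, a step that the two limits leave unreadable from compound 1 to compound 3 and a step that the two limits leave unreadable from compound 2 to compound 3. None has a readable size, and none changes the chain, so they give only weak guidance. A modest gain in this assay is expected, though a further limit remains quite possible. The estimated step is an at least 1.4-fold lower number from compound 1 to compound 4 (0.15 log units; that floor lies within the scatter). For compound 4 the expected value is 35000 nM, with an estimated range of 10000 nM to 100000 nM.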

Compound 4, half-maximal inhibitory concentration: 3320 nM
Compound 4: the middle estimate sits 11-fold (1.02 log units) above what was measured, and the stated range ends above it.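

Butyl in place of hydrogen on this saturated chain carbon, seven bonds along the chain from an aromatic nitrogen, gives an at least 15-fold lower number from compound 1 to compound 4 (1.17 log units; beyond the scatter) in this assay. The steps among compound 1, compound 2 and compound 3 cannot be read, so this chain position is the only place in the series where a change has a readable size. Compound 4 alone stands clear of the limit that holds the other compounds: the limit of > 50000 nM in this assay, at which 3 of the 4 values shown sit.

From the compounds shown here alone, whether butyl acts the same way with amino or hydrogen in place of dimethylamino remains open. So does whether a longer chain goes further.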